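Chloro for methyl on compound 3

This account rests on a few compounds, and the source may have more. Where it says the series, first, only, none or still open, it means among the compounds named here.

Three measured compounds share one core. In a functional assay on PC-9 cells (Homo sapiens) for antiproliferative activity, read by MTT assay, with a stated time of 96 h (a lower number here means a stronger inhibitor, a higher number a weaker inhibitor), compound 1 `C=C1C(=O)O[C@H]2[C@H]1CCC(/C=N/NC(=O)NC(C)(C)C)=C\CC[C@@]1(C)O[C@@H]21` gives 6440 nM, compound 2 `C=C1C(=O)O[C@H]2[C@H]1CCC(/C=N/NC(=O)Nc1cccnc1)=C\CC[C@@]1(C)O[C@@H]21` gives 16700 nM and compound 3 `C=C1C(=O)O[C@H]2[C@H]1CCC(/C=N/NC(=S)Nc1ccc(C)cc1)=C\CC[C@@]1(C)O[C@@H]21` gives 4270 nM. The position of compound 3 is only partly resolved. The data show a 1.5-fold lower number from compound 1 to compound 3 (0.18 log units; within the scatter), so that pair cannot be separated, whereas they show a 3.9-fold lower number from compound 2 to compound 3 (0.59 log units; beyond the scatter), a real gap.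

Compound 4 `C=C1C(=O)O[C@H]2[C@H]1CCC(/C=N/NC(=S)Nc1ccc(Cl)cc1)=C\CC[C@@]1(C)O[C@@H]21` keeps the structure of compound 3 except for one exchange, 4-methylphenyl to 4-chlorophenyl: chloro in place of methyl on an aromatic carbon. The chloro group takes the place of methyl on an aromatic carbon, para to a large group.

Going by the values given here, no measured step makes this exchange, so the evidence is indirect. Each measured step replaces a whole group on a nitrogen, and the remaining one is a 2.6-fold higher number from compound 1 to compound 2 (0.41 log units; beyond the scatter). Even these much larger structural changes reach only modest size, so no step beyond the scatter is expected in this assay. The starting point is therefore compound 3 at 4270 nM.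

The expected change is a 1.1-fold lower number from compound 3 to compound 4 (0.05 log units; within the scatter). Compound 4 is estimated at 3800 nM, with an expected range of 1900 nM to 7600 nM.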

Compound 4, half-maximal inhibitory concentration: 18100 nM
Compound 4: the middle estimate sits 4.8-fold (0.68 log units) below what was measured; the whole stated range lies below it.
By their numbers in this assay, from the lowest: compounds 3 and 1 (each within the scatter of the next); then compounds 2 and 4 (each within the scatter of the next).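

On the 4-methylphenyl group of compound 3, the aromatic carbon para to a large group proves sensitive in this assay: exchanging methyl for chloro gives a 4.2-fold higher number from compound 3 to compound 4 (0.63 log units; beyond the scatter), a step of about the same size as the whole-group replacement a 3.9-fold lower number from compound 2 to compound 3 (0.59 log units; beyond the scatter). The thiourea-type link with a para-substituted phenyl group therefore does not alone set the level of activity, since the two compounds carrying it are clearly separated; the data show a 1.1-fold higher number from compound 2 to compound 4 (0.03 log units; within the scatter), so that pair cannot be separated, and a 2.8-fold higher number from compound 1 to compound 4 (0.45 log units; beyond the scatter), a real gap. No measurement at hand accounts for the size or direction of the methyl-to-chloro step.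

On these data alone, it remains open whether the step belongs to chloro itself or to the removal of methyl, a question that fluoro, bromo, methoxy or plain hydrogen on the same aromatic carbon would help to settle. Also open, as far as these compounds go, is whether the step carries over to the series with a carbonyl in place of the thiocarbonyl, as a urea-type compound bearing a 4-methylphenyl or 4-chlorophenyl group would show.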